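Replacing a large benzyl group with small dimethylamino

The source may hold more compounds than are shown below. What is called first, only, known or untested is meant among the compounds shown, and "the series" means these compounds.

Of the compounds shown here, three built on one shared core have been measured in a functional assay on CHO cells for agonist activity at Free fatty acid receptor 2 (Homo sapiens), read by cAMP accumulation; on this read-out higher numbers stand for weaker inhibition and lower numbers for stronger inhibition. Compound 1 `CC(C)(C)[C@H](C(=O)Nc1ncc(C(F)(F)F)s1)c1ccc(Cl)cc1` carries a trifluoromethyl group on the five-membered aromatic ring with 1 nitrogen and 1 sulfur, and in this assay compound 1 gives 1500 nM. Compound 2 `CSc1cnc(NC(=O)[C@H](c2ccc(Cl)cc2)C(C)(C)C)s1` carries methylsulfanyl in the same place, and in this assay compound 2 gives 500 nM. Compound 3 `CC(C)(C)[C@H](C(=O)Nc1ncc(Cc2ccc(Cl)cc2)s1)c1ccc(Cl)cc1` carries 4-chlorobenzyl there, and in this assay compound 3 gives 25000 nM, the highest of the three numbers. The steps between them read: a 3.0-fold lower number from compound 1 to compound 2 (0.48 log units; beyond the scatter), a 17-fold higher number from compound 1 to compound 3 (1.22 log units; beyond the scatter), and a 50-fold higher number from compound 2 to compound 3 (1.70 log units; beyond the scatter). Both small groups thus give far lower numbers than the large benzyl group.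

Compound 4 `CN(C)c1cnc(NC(=O)[C@H](c2ccc(Cl)cc2)C(C)(C)C)s1` is not yet measured. It differs from compound 3 by dimethylamino in place of 4-chlorobenzyl on an aromatic carbon. The two steps that bear on this are those that introduced 4-chlorobenzyl in place of a small group: from compound 1 and from compound 2, each a large rise in the number. Compound 4 reverses that kind of change, so a large fall, of similar size, is expected. Compound 4 is therefore estimated at 1000 nM, with a range from 300 nM to 4000 nM, which means an expected 25-fold lower number from compound 3 to compound 4 (1.40 log units; beyond the scatter).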

Compound 4, half-maximal inhibitory concentration: 1600 nM
The estimate for compound 4 lay 1.6-fold (0.20 log units) below the measured number; measured number inside the range.
By their numbers in this assay, from the lowest: compound 2; then compounds 1 and 4 (each within the scatter of the next); then compound 3.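

In this assay, a third small group now stands against 4-chlorobenzyl at this place next to the ring sulfur, with a 16-fold lower number from compound 3 to compound 4 (1.19 log units; beyond the scatter), so the earlier contrast between small groups and this large one holds for all three small groups shown. The small groups are not all alike, however: there is a 3.2-fold higher number from compound 2 to compound 4 (0.51 log units; beyond the scatter), which leaves methylsulfanyl with the lowest number of the four groups, whereas a 1.1-fold higher number from compound 1 to compound 4 (0.03 log units; within the scatter) gives dimethylamino and trifluoromethyl no real separation. No measurement of any property of these groups is available to explain these differences.

Among the compounds shown here, with only one large group in the set, it remains open whether the high number belongs to large groups in general or to 4-chlorobenzyl in particular, and a plain benzyl group without the chlorine or a longer alkyl chain would help to separate those two readings. Among the small groups, a methoxy group or an ethylsulfanyl chain would show whether the lower number of compound 2 extends beyond methylsulfanyl itself.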